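This account rests on a few compounds, and the source may have more. Where it says the series, first, only, none or still open, it means among the compounds named here.

Working notes on the series, step from compound 2 to compound 4.

The compounds share a diaryl urea bearing a trifluoromethyl group, linked through an ether to a pyrimidine. Compound 2 `O=C(Nc1ccc(Oc2ccncn2)cc1)Nc1cccc(C(F)(F)F)c1` carries no substituent on that pyrimidine; in an assay on isolated protein for inhibition of serine/threonine-protein kinase TNNI3K (Homo sapiens) (a higher number here means a weaker inhibitor, a lower number a stronger inhibitor), compound 2 gives 160 nM, the highest of the two plain numbers shown. Compound 1 `CNc1cc(Oc2c(C)cc(NC(=O)Nc3cccc(C(F)(F)F)c3)cc2C)ncn1` gives 25 nM in this assay. Compound 3 `CNc1cc(Oc2ccc(NC(=O)Nc3cccc(C(F)(F)F)c3)cc2C)ncn1` sits at the limit <= 10 nM in this assay, so only a limit is known for it (the limit of <= 10 nM in this assay, at which 1 of the 3 values shown sits). For the measured compounds named here, the one counted step, an at least 2.5-fold lower number from compound 1 to compound 3 (0.39 log units; beyond the scatter), concerns a methyl on the middle ring and does not touch the pyrimidine.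

Compound 4 `CCNc1cc(Oc2ccc(NC(=O)Nc3cccc(C(F)(F)F)c3)cc2)ncn1` differs from compound 2 by ethylamino in place of hydrogen on an aromatic carbon. Going by the values given here, no measured step covers this change directly; what the values show is that compound 1 and compound 3, both carrying methylamino on the pyrimidine, give lower numbers than compound 2. Ethylamino is expected to behave like methylamino, so a step of a 6.4-fold lower number from compound 2 to compound 4 (0.81 log units; beyond the scatter) is estimated, and compound 4 is expected to give 25 nM in this assay, within 8 nM to 70 nM.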

Compound 4, half-maximal inhibitory concentration: 25 nM
Beside the measured number, compound 4's estimate shows no gap at the digits printed, and the stated range covers the measured number.
By their numbers in this assay, from the lowest: compounds 1 and 4 (each within the scatter of the next); then compound 2. At a limit, below all of these: compound 3.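

For the compounds shown here, the step of a 6.4-fold lower number from compound 2 to compound 4 (0.81 log units; beyond the scatter) is the first direct reading of this position in this assay: ethylamino replaces hydrogen on an aromatic carbon next to the ring nitrogen, and nothing else in the structure changes. Compound 1 and compound 3 also carry an amino substituent at this place, but each differs from compound 2 elsewhere as well, so neither could isolate the effect of the substituent. The step lies beyond the scatter, so the gain in this assay can now be assigned to this single change, although the values give no cause for it.

On these data alone, whether the plain amino group, a longer chain or a cyclic amine such as morpholine would give a similar step remains open. Compound 3 is known only as a limit, so its place among the others stays unresolved: the limit of <= 10 nM in this assay, at which 1 of the 4 values shown sits.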